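The source may report more compounds than this note shows. Statements on the series, on what has been measured and on what is new or still open speak of the compounds shown alone.

Measured so far:
- compound 1 `c1cc2ncc(-c3nn[nH]n3)cc2cc1OC1CCCCC1`: 10 mg/kg
- compound 2 `Cc1ccc2cc(C(=O)O)cnc2c1C`: 50 mg/kg

In a functional assay on the whole organism (strain Sprague-Dawley) for inhibition, with Rattus norvegicus as the target (on this read-out higher numbers stand for an effect only at larger amounts of compound and lower numbers for an effect already at smaller amounts), compound 1 gives 10 mg/kg, the lower of the two numbers available. Compound 2 gives 50 mg/kg in this assay, a higher number than compound 1, and the gap between the two lies beyond the usual scatter. The two compounds differ in more than one place, so the gap is not tied to any single change.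

Compound 3 `c1ccc2ncc(-c3nn[nH]n3)cc2c1` is the next candidate for this assay. It differs from compound 1 in one place: hydrogen in place of cyclohexyloxy on an aromatic carbon. Among the measured compounds shown here, no measured pair shows this change, so its effect is open. The expectation is that removing a group of this size is more likely to weaken than to strengthen the effect, so a step toward a higher number from compound 1 to compound 3 is estimated, a 3.0-fold higher number from compound 1 to compound 3 (0.48 log units; beyond the scatter), beyond the scatter. For compound 3 the estimated minimum effective dose is 30 mg/kg, with a range from 10 mg/kg to 100 mg/kg.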

Compound 3, minimum effective dose: 25 mg/kg
Compound 3: the middle estimate sits 1.2-fold (0.08 log units) above what was measured; low and high end bracket the measured number.
By their numbers in this assay, from the lowest: compound 1; then compounds 3 and 2 (each within the scatter of the next).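

In this assay, among the compounds shown here, hydrogen in place of cyclohexyloxy on an aromatic carbon gives a 2.5-fold higher number from compound 1 to compound 3 (0.40 log units; beyond the scatter), the first single-place comparison, and it is a modest step beyond the usual scatter. The effect does not depend entirely on the cyclohexyloxy group: without it, compound 3 still gives 25 mg/kg in this assay, so the core of compound 3 retains an effect at a measurable dose. No available measurement bears on the reason for this step.

On these data alone, whether a smaller ether such as methoxy, an amine or a carboxylic acid on this aromatic carbon would give a number closer to that of compound 1 or compound 3 remains open. As far as these compounds go, it is also open whether this step would carry over to a different core.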